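A few compounds are considered here, and "the series" means these few. Any claim that something is new, unique, unknown or untested is made for them only; others in the source may bear on it.

Measured compounds:
- Compound 1 `COc1cc(/C=C/C(=O)c2cccc(-n3cc(-c4ccc(Cl)cc4)[nH]c3=O)c2)cc(OC)c1OC`: "not active" (no number reported)
- Compound 2 `O=C(/C=C/c1cccc(O)c1)c1cccc(-n2cc(-c3ccc(Cl)cc3)[nH]c2=O)c1`: 1460 nM

Two compounds share a core and were tested in a functional assay on SNB-75 cells (Homo sapiens) for inhibition; on this read-out lower numbers stand for stronger inhibition of growth and higher numbers for weaker inhibition of growth. Compound 2 carries a hydroxyl on its outer ring and in this assay gives 1460 nM. Compound 1 carries three methoxy groups on that ring and in this assay was reported as "not active" (no number reported), so no single number places it on the scale; all that is known is that it stands on the weak side.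

Compound 3 `COc1ccc(-c2cn(-c3cccc(C(=O)/C=C/c4cc(OC)c(OC)c(OC)c4)c3)c(=O)[nH]2)cc1` is compound 1 with one change: methoxy in place of chloro on an aromatic carbon. Among the measured compounds shown here, no pair of measured compounds shows what this exchange does here, so the size and direction of the step are unknown; with compound 1 already without a reported number, the expectation is that compound 3 also stays weak. The growth-inhibiting concentration of compound 3 is estimated at 30000 nM, within a range of 5000 nM to 150000 nM.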

Compound 3, concentration for 50% growth inhibition: 4590 nM
For compound 3 the middle estimate is 6.5-fold (0.82 log units) above the measured one; measured number below the stated range.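

Compound 1 has no reported number, so no step can be read between it and compound 3. No available evidence bears on this result. The compounds shown leave open how far 4-chlorophenyl to 4-methoxyphenyl alone shifts growth inhibition.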